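Phenyl in Place of Hydrogen on the Shared Core

The source may report more compounds than this note shows. Statements on the series, on what has been measured and on what is new or still open speak of the compounds shown alone.

Measured so far in an assay on tissue (HeLa cells) for inhibition of Indoleamine 2,3-dioxygenase 1 (Homo sapiens), read by spectrophotometry; a higher number here means a weaker inhibitor, a lower number a stronger inhibitor:

Compound 1, `O/N=C(/Nc1ccccc1)c1ccc2occc2c1`, gives 19000 nM.
Compound 2, `O/N=C(/Nc1cccc(Br)c1)c1ccc2occc2c1`, gives 1100 nM.
Compound 3, `Cc1ccc(N/C(=N/O)c2ccc3occc3c2)cc1C`, gives only a limit of > 30000 nM, so no number is known for it.

Among the two numbers shown, compound 1 stands highest; its nearest neighbour is compound 2, reached through a 17-fold lower number from compound 1 to compound 2 (1.24 log units; beyond the scatter). Compound 3 sits at the limit noted in the limit of > 30000 nM in this assay, at which 1 of the 3 values shown sits, which tells nothing about its size beyond that.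

Compound 4, `O/N=C(/Nc1cccc(-c2ccccc2)c1)c1ccc2occc2c1`, is not yet measured. It differs from compound 1 by one change: phenyl in place of hydrogen on an aromatic carbon.

Within the data shown here, only one measured step speaks to this change, the one from compound 1 to compound 2, where a bromo group entered in place of a hydrogen on an aromatic carbon and the number fell by a large amount. Among the measured compounds shown here, a phenyl group entering at an aromatic carbon is a different kind of group, so that step is a guide rather than a rule, and no second example shows whether a larger group behaves the same way. A step downward, smaller than that seen with bromo, is expected in this assay.

For compound 4 the expected value in this assay is 4000 nM, within a range from 900 nM to 18000 nM, which amounts to an estimated step of a 4.8-fold lower number from compound 1 to compound 4 (0.68 log units; beyond the scatter).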

Compound 4, half-maximal inhibitory concentration: 11900 nM
Estimate against measurement, compound 4: 3.0-fold (0.47 log units) below; low and high end bracket the measured number.
By their numbers in this assay, from the lowest: compound 2; then compounds 4 and 1 (each within the scatter of the next). At a limit, above all of these: compound 3.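

In this assay, the same aromatic carbon responds very differently to two groups. Phenyl in place of hydrogen leaves compound 4 within the scatter of compound 1 (a 1.6-fold lower number from compound 1 to compound 4 (0.20 log units; within the scatter)), while phenyl in place of bromo is a large step in the other direction (an 11-fold higher number from compound 2 to compound 4 (1.03 log units; beyond the scatter)). The gain that bromo brought therefore does not extend to every group placed on this carbon, and a hydrogen and a phenyl ring here cannot be told apart in this assay, although bromo stands clearly apart from both; nothing shown speaks to the reason for this.

Among these compounds, only three groups have been compared on this carbon, so it remains open which feature of bromo matters, and whether chloro, an amine, a methoxy group or a carboxylic acid at the same place would follow bromo or phenyl. From the compounds shown here alone, it is also open whether bromo or phenyl would give the same results on the other carbons of that ring, or whether a longer chain ending in a phenyl ring would behave as the phenyl group does.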